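A Second Methyl Next to the Ring Nitrogen

The source may hold more compounds than are shown below. What is called first, only, known or untested is meant among the compounds shown, and "the series" means these compounds.

Measured in a functional assay on HepG2 cells (Homo sapiens) for antiproliferative activity, read by MTT assay, with a stated time of 72 h; a lower number here means a stronger inhibitor, a higher number a weaker inhibitor:
Compound 1, `C=C(c1ccncc1)c1ccc(OC)c(O)c1`, gives 261 nM.
Compound 2, `C=C(c1ccnc(C)c1)c1ccc(OC)c(O)c1`, gives 31 nM.
Compound 3, `C=C(c1ccnc(C)c1)c1ccc2[nH]ccc2c1`, gives 33 nM.

Compound 1 and compound 2 share one core and differ only in the change (methyl in place of hydrogen on an aromatic carbon). That single change produced an 8.4-fold lower number from compound 1 to compound 2 (0.93 log units; beyond the scatter). Compound 3 has a different core; how its core differs from that of compound 1 is not broken down here. Its number sits within the scatter of that of compound 2, so the two cannot be ordered.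

Compound 4, `C=C(c1cc(C)nc(C)c1)c1ccc2[nH]ccc2c1`, carries the change (methyl in place of hydrogen on an aromatic carbon). Among the compounds with values here, this is the same kind of change as the one from compound 1 to compound 2, not the same: the place in compound 4 is also meta to a methyl group, which the place in compound 2 is not. Because an 8.4-fold lower number from compound 1 to compound 2 (0.93 log units; beyond the scatter) was modest, and because compound 3 already gives 33 nM, a smaller step is expected in this assay, a 1.7-fold lower number from compound 3 to compound 4 (0.22 log units; within the scatter). Compound 4 is therefore estimated at 20 nM, between 6 nM and 70 nM.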

Compound 4, half-maximal inhibitory concentration: 30 nM
Compound 4: the middle estimate sits 1.5-fold (0.18 log units) below what was measured; measured number inside the range.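

In this assay, putting a methyl in place of hydrogen next to the ring nitrogen gave a 1.1-fold lower number from compound 3 to compound 4 (0.04 log units; within the scatter), so compound 3 and compound 4 cannot be ordered. The same kind of change therefore did not carry over at the same size from one core to the other: the same change on two cores in this assay, an 8.4-fold lower number (0.93 log units; beyond the scatter) from compound 1 to compound 2 and a 1.1-fold lower number (0.04 log units; within the scatter) from compound 3 to compound 4, 7.7-fold (0.88 log units) apart, beyond the scatter of two such steps

This does not show why the two steps differ, since they differ in the core and also in the place, the new methyl being meta to a methyl group while the earlier one is not, and two steps give no rule for any further core.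

The compounds shown leave open what a single methyl would do on the core of compound 3 with no other methyl on the nitrogen-bearing ring, which would separate those two explanations. They also leave open how a larger or different group in the same place, such as an ethyl group or an amine, would compare with the methyl.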